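A hydroxyphenyl analogue of the triazolyl pyridine urea series

The compounds below may be only part of what the source reports. "The series", "measured", "known", "first", "only" and "open" are said of these compounds alone.

Of the compounds shown here, three sharing one core have been tested in a functional assay on MKN-45 cells (Homo sapiens) for cytotoxicity, read by MTT assay, with a stated time of 72 h; on this read-out lower numbers stand for stronger inhibition and higher numbers for weaker inhibition. Compound 1 `CN(C)CCn1cnnc1-c1cc(Oc2ccc(NC(=O)N/N=C/c3ccc(Cl)cc3Cl)cc2F)ccn1` gives 750 nM, compound 2 `COc1ccc(/C=N/NC(=O)Nc2ccc(Oc3ccnc(-c4nncn4CCN(C)C)c3)c(F)c2)c(OC)c1` gives 1680 nM, and compound 3 `CN(C)CCn1cnnc1-c1cc(Oc2ccc(NC(=O)N/N=C/c3ccc(Cl)cc3)cc2F)ccn1` gives 570 nM, the lowest of the three numbers, though only the gap to compound 2 lies beyond the scatter. The steps show a 1.3-fold lower number from compound 1 to compound 3 (0.12 log units; within the scatter), a 2.2-fold higher number from compound 1 to compound 2 (0.35 log units; beyond the scatter), and a 2.9-fold lower number from compound 2 to compound 3 (0.47 log units; beyond the scatter).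

Compound 4 `CN(C)CCn1cnnc1-c1cc(Oc2ccc(NC(=O)N/N=C/c3cccc(O)c3)cc2F)ccn1` differs from compound 3 in one place: 3-hydroxyphenyl in place of 4-chlorophenyl on a carbon with a double bond to nitrogen. For the measured compounds named here, no measured step carries exactly this change. The nearest precedents are the two steps in which an oxygen-bearing aromatic ring replaced or was replaced by a chlorinated one, a 2.2-fold higher number from compound 1 to compound 2 (0.35 log units; beyond the scatter) and a 2.9-fold lower number from compound 2 to compound 3 (0.47 log units; beyond the scatter), both modest and both with the oxygen-bearing ring giving the higher number. On that basis a modest rise in this assay is expected, a 1.9-fold higher number from compound 3 to compound 4 (0.29 log units; within the scatter), and compound 4 is estimated at 1100 nM, within a range of 400 nM to 3000 nM.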

Compound 4, half-maximal inhibitory concentration: 1370 nM
Compound 4: middle estimate off by 1.2-fold (0.10 log units), on the low side; low and high end bracket the measured number.
By their numbers in this assay, from the lowest: compounds 3, 1, 4 and 2 (each within the scatter of the next, the first and the last beyond it).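

In this assay, for the compounds shown here, putting 3-hydroxyphenyl in place of 4-chlorophenyl on the carbon with a double bond to nitrogen gives a 2.4-fold higher number from compound 3 to compound 4 (0.38 log units; beyond the scatter), so a second oxygen-bearing ring, after the one in compound 2, stands apart from 4-chlorophenyl beyond the scatter. The two oxygen-bearing rings are not told apart, with a 1.2-fold lower number from compound 2 to compound 4 (0.09 log units; within the scatter), even though one carries a single hydroxyl and the other two methoxy groups. The 2,4-dichlorophenyl ring does not separate from 3-hydroxyphenyl either, with a 1.8-fold higher number from compound 1 to compound 4 (0.26 log units; within the scatter), and compound 4 therefore goes against any reading that chlorinated rings always give the lower number.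

Going by these compounds, how an aminophenyl or a carboxyphenyl ring on this carbon would compare with 3-hydroxyphenyl stays open. Nothing given here explains the rise from compound 3 to compound 4.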